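Swapping One Methoxyphenyl for Another

A few compounds are considered here, and "the series" means these few. Any claim that something is new, unique, unknown or untested is made for them only; others in the source may bear on it.

Compound 1 (`COc1cc(/C=C/c2nnc(NC(=O)c3cccc(O)c3)s2)c(Br)c(OC)c1OC`) gives 220 nM in a functional assay on HepG2 cells (Mus musculus) for antiproliferative activity against HepG2 (Homo sapiens), read by MTT assay, with a stated time of 48 h (a lower number here means a stronger inhibitor, a higher number a weaker inhibitor), and compound 2 (`COc1ccc(/C=C/c2nnc(NC(=O)c3cc(OC)c(OC)c(OC)c3Br)s2)cc1`) gives 210 nM there. These two numbers lie within the usual scatter of each other, so compound 2 stands level with compound 1 and neither can be ranked ahead.

Compound 3 (`COc1cccc(/C=C/c2nnc(NC(=O)c3cc(OC)c(OC)c(OC)c3Br)s2)c1`) has the same atoms as compound 2, joined differently (3-methoxyphenyl in place of 4-methoxyphenyl on a double-bonded chain carbon bound to a double-bonded chain carbon). In words, it carries 3-methoxyphenyl in place of 4-methoxyphenyl on a double-bonded chain carbon bound to a double-bonded chain carbon. Among the measured compounds shown here, compounds 1 and 2 differ in more than one place, and no measured pair shows this change on its own, so the data give no direct guide to its size or direction.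

Compound 2 at 210 nM is the closest measured reference, so the expectation starts from that number and allows a modest drift toward weaker inhibition. The expected step (a 1.4-fold higher number from compound 2 to compound 3 (0.15 log units; within the scatter)) is small and may not exceed the scatter. For compound 3 the estimated value is 300 nM with an expected range from 110 nM to 850 nM as the likely span.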

Compound 3, half-maximal inhibitory concentration: 210 nM
Compound 3: the middle estimate sits 1.4-fold (0.15 log units) above what was measured; low and high end bracket the measured number.
By their numbers in this assay, from the lowest: compounds 2, 3 and 1 (each within the scatter of the next).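

Among the compounds shown here, this is the first pair in the set that differs in only one place, so it gives the first direct reading of this change: with the rest of compound 2 held fixed, placing 3-methoxyphenyl in place of 4-methoxyphenyl on a double-bonded chain carbon bound to a double-bonded chain carbon gives no change at the digits printed from compound 2 to compound 3 (within the scatter) in this assay. In this one pair, then, the two arrangements of the same atoms cannot be told apart by this read-out, and the activity does not depend measurably on which of the two methoxyphenyl groups is present. No measurement at hand gives any independent information on why the two compounds read alike.

Going by these compounds, what remains open is whether this level reading is specific to the methoxy group or extends to other groups on that phenyl ring, such as an ethoxy group, an amine or a carboxylic acid. A single pair on a single core also cannot show whether the same swap would read alike when the other end of the molecule carries the 3-hydroxybenzamide part seen in compound 1.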